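The source may report more compounds than this note shows. Statements on the series, on what has been measured and on what is new or still open speak of the compounds shown alone.

Measured in a functional assay on MDA-MB-231 cells (Homo sapiens) for antiproliferative activity, read by sulforhodamine B assay, with a stated time of 72 h; a lower number here means a stronger inhibitor, a higher number a weaker inhibitor:
- compound 1 `COc1ccc(O)c(C(=O)/C=C/c2csc3ccccc23)c1`: 760 nM
- compound 2 `COc1ccc(C(=O)/C=C/c2csc3ccccc23)c(O)c1`: 7400 nM

Of these two compounds, compound 2 stands highest at 7400 nM, the weaker of the pair. Compound 1 lies lower by more than the usual scatter of repeated measurements. Compound 3 `COc1cc(O)c(C(=O)/C=C/c2csc3ccccc23)cc1OC` has not yet been measured. It departs from compound 2 by one change, methoxy in place of hydrogen on an aromatic carbon. Among the compounds with values here, no step between measured compounds is available as a guide, so the expectation rests on a comparison. Compound 1, which gives 760 nM, also carries a methoxy para to a hydroxy group. A move toward a lower number in this assay is therefore expected, though perhaps not all the way to that value. The estimated change is a 4.1-fold lower number from compound 2 to compound 3 (0.61 log units; beyond the scatter). For compound 3 the expected value is 1800 nM, with an estimated range of 400 nM to 7000 nM.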

Compound 3, half-maximal inhibitory concentration: 690 nM
Compound 3: the middle estimate sits 2.6-fold (0.42 log units) above what was measured; measured number inside the range.
By their numbers in this assay, from the lowest: compounds 3 and 1 (each within the scatter of the next); then compound 2.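

In this assay, placing a methoxy para to the hydroxy group, ortho to the methoxy group already present, gives an 11-fold lower number from compound 2 to compound 3 (1.03 log units; beyond the scatter), so this position responds strongly to this change. Compound 1 already carries a methoxy para to the hydroxy group, and adding the further methoxy found in compound 3 gives a 1.1-fold lower number from compound 1 to compound 3 (0.04 log units; within the scatter), so the second methoxy adds nothing measurable once this position is filled. Nothing shown here explains the size of the first step.

The compounds shown leave open whether methoxy itself is required at this position, or whether a hydroxy, an ethoxy or a fluorine there would give a similar number. They also leave open whether an amine at this position would keep the gain.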